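This account rests on a few compounds, and the source may have more. Where it says the series, first, only, none or still open, it means among the compounds named here.

In a functional assay on K562 cells (Homo sapiens) for antiproliferative activity, read by luminescence, with a stated time of 72 h (a higher number here means a weaker inhibitor, a lower number a stronger inhibitor), compound 2 `CN1CC=C(c2c(O)cc(O)c3c(=O)cc(-c4ccc(Sc5nc6ccccc6n5C)cc4Cl)oc23)CC1` stands lowest of the two measured compounds with 50.8 nM and compound 1 `CN1CC=C(c2c(O)cc(O)c3c(=O)cc(-c4ccc(Sc5nc6ccccc6[nH]5)cc4)oc23)CC1` gives 194 nM as a higher number beyond the scatter. Compound 3 `CN1CC=C(c2c(O)cc(O)c3c(=O)cc(-c4ccc(Sc5nc6ccccc6[nH]5)cc4Cl)oc23)CC1` differs from compound 2 by hydrogen in place of methyl on an aromatic nitrogen as hydrogen in place of methyl on an aromatic nitrogen. Among the compounds with values here, no measured pair shows this change alone. Within the data shown here, compound 1 at 194 nM is the only higher number to lean on. A modest rise is therefore expected in this assay with an estimated 2.0-fold higher number from compound 2 to compound 3 (0.29 log units; within the scatter) as the step. Compound 3 is estimated at 100 nM with 35 nM to 280 nM as the expected range.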

Compound 3, half-maximal inhibitory concentration: 36 nM
Compound 3: the middle estimate sits 2.8-fold (0.44 log units) above what was measured, and the stated range covers the measured number.
By their numbers in this assay, from the lowest: compounds 3 and 2 (each within the scatter of the next); then compound 1.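

In this assay, the methyl on the aromatic nitrogen can be removed with the chloro group in place, and the step (a 1.4-fold lower number from compound 2 to compound 3 (0.15 log units; within the scatter)) stays within the scatter, so the 1-methyl-1H-benzimidazol-2-yl and 1H-benzimidazol-2-yl forms cannot be told apart here. Chloro in place of hydrogen on an aromatic carbon, by contrast, gives a modest step beyond the scatter (a 5.4-fold lower number from compound 1 to compound 3 (0.73 log units; beyond the scatter)). No supporting measurement accounts for either step. From the compounds shown here alone, whether an ethyl group or a longer chain on that nitrogen would hold the number remains open, as does how the methyl behaves without the chloro group.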